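The source may report more compounds than this note shows. Statements on the series, on what has been measured and on what is new or still open speak of the compounds shown alone.

Measured compounds in a physicochemical assay for lipophilicity, at pH 7.4; on this read-out lower numbers stand for lower lipophilicity and higher numbers for higher lipophilicity:

Compound 1 `Cc1cc(C(=O)NC(C)C)nn1Cc1cc(Cl)ccc1OCc1ccccc1` gives > 3.7, a limit of the assay and not a number.
Compound 2 `Cc1cc(C(=O)Nc2ccccc2)nn1Cc1cc(Cl)ccc1OCc1ccccc1` gives > 3.7, likewise a limit.
Compound 3 `Cc1cc(NC(=O)C2CCOC2)nn1Cc1cc(Cl)ccc1OCc1ccccc1` gives > 3.7, again a limit.

Compound 2 thus stands only at a limit of this assay; no number is available for it, and the same holds for every value shown, since (the limit of > 3.7 in this assay, at which 3 of the 3 values shown sit). Compound 4 `Cc1cc(NC(=O)C2CCOCC2)nn1Cc1cc(Cl)ccc1OCc1ccccc1` is the compound still to be measured. It differs from compound 2 in one place: ((oxan-4-yl)carbonyl)amino in place of phenylcarbamoyl on an aromatic carbon.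

The measured steps that could bear on this change are a step that the two limits leave unreadable from compound 1 to compound 2, a step that the two limits leave unreadable from compound 1 to compound 3 and a step that the two limits leave unreadable from compound 2 to compound 3. Each of them runs from one limit to another, so none has a readable size, and none gives a direction. The closest parallel is a step that the two limits leave unreadable from compound 2 to compound 3, ((oxolan-3-yl)carbonyl)amino in place of phenylcarbamoyl, which ends at the same limit as it starts. The step that the limit leaves unreadable from compound 2 to compound 4 is therefore expected to be small, with no direction claimed beyond the scatter, and the value of compound 4 is expected to remain near the limit. Compound 4 is estimated at 3.9, between 3.4 and 4.6, with a real chance that this assay again reports only a limit.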

Compound 4, distribution coefficient: > 3.7
Compound 4 gave a limit, no number; the forecaster's own chance of this, stated with the estimate: 60%; the middle value lies beyond the limit too.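

In this assay compound 4 gives > 3.7, a limit and not a number. No step from compound 1, compound 2 or compound 3 to compound 4 can be read: the limit of > 3.7 in this assay, at which 4 of the 4 values shown sit.

The compounds shown leave open how far compound 1, compound 2, compound 3 and compound 4 lie apart on this read-out, and in which order.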